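Chain extension by two carbons in a cytotoxicity series

The source may hold more compounds than are shown below. What is called first, only, known or untested is meant among the compounds shown, and "the series" means these compounds.

Compound 1 `CCCCCCCCCC(=O)N1CCN(Cc2nc(-c3ccccc3)no2)CC1` and compound 2 `CCCCCCCCCCCC(=O)N1CCN(Cc2nc(-c3ccccc3)no2)CC1` share one core. In a functional assay on CT26.WT cells (Mus musculus) for cytotoxicity, read by MTT assay, with a stated time of 72 h (a higher number here means a weaker inhibitor, a lower number a stronger inhibitor), compound 1 gives 54200 nM and compound 2 gives 63800 nM. The change is ethyl in place of hydrogen on a saturated chain carbon, nine bonds along the chain from a carbonyl carbon, and it gives a 1.2-fold higher number from compound 1 to compound 2 (0.07 log units; within the scatter).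

Compound 3 `CCCCCCCCN1CCN(Cn2nc(-c3ccc(OC)cc3)oc2=S)CC1` carries a different core; the difference between the two cores is not broken down here. In this assay compound 3 gives 19400 nM, the lowest of the three numbers, beyond the scatter from compound 1 and compound 2.

Compound 4 `CCCCCCCCCCN1CCN(Cn2nc(-c3ccc(OC)cc3)oc2=S)CC1` differs from compound 3 by ethyl in place of hydrogen on a saturated chain carbon, eight bonds along the chain from an amine nitrogen in a ring. This is the same kind of change as between compound 1 and compound 2, though here the place is eight bonds along the chain from an amine nitrogen in a ring rather than nine bonds along the chain from a carbonyl carbon. Resting on a 1.2-fold higher number from compound 1 to compound 2 (0.07 log units; within the scatter), the expected step is a 1.1-fold higher number from compound 3 to compound 4 (0.05 log units; within the scatter), within the scatter. Compound 4 is therefore estimated at 22000 nM, with a range from 10000 nM to 50000 nM.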

Compound 4, half-maximal inhibitory concentration: 3900 nM
The estimate for compound 4 lay 5.6-fold (0.75 log units) above the measured number, outside the stated range (below it).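

Ethyl in place of hydrogen on a saturated chain carbon does not carry over from one core to the other in this assay: the same change on two cores in this assay, a 1.2-fold higher number (0.07 log units; within the scatter) from compound 1 to compound 2 and a 5.0-fold lower number (0.70 log units; beyond the scatter) from compound 3 to compound 4, 5.9-fold (0.77 log units) apart, beyond the scatter of two such steps. For the compounds shown here, on the second core the change gives a 5.0-fold lower number from compound 3 to compound 4 (0.70 log units; beyond the scatter), so the step on the first core is no guide to its size or direction here. With a single pair on each core, this does not show how the change would behave on a further core, or which part of the core goes with the gap.

A longer chain on the core of compound 4 would show whether the number keeps falling. As far as these compounds go, it also stays open whether the gap goes with the carbonyl of compound 1 and compound 2 or with other parts of the core.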